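A few compounds are considered here, and "the series" means these few. Any claim that something is new, unique, unknown or untested is made for them only; others in the source may bear on it.

Compound 1 `CC(C)(C)OC(=O)N1CCC(O[C@H]2CC[C@@H](Oc3ccc(S(C)(=O)=O)cc3)CC2)CC1` gives 266 nM in a functional assay on isolated protein for agonist activity at Glucose-dependent insulinotropic receptor (Homo sapiens), read by HTRF and cAMP accumulation; a higher number here means that more compound is needed for the effect, a lower number that less compound is needed. Compound 2 `CC(C)(C)OC(=O)N1CCC(O[C@H]2CC[C@H](Oc3ccc(S(C)(=O)=O)cc3)CC2)CC1` gives 16.1 nM in this assay. Compound 3 `CC(C)(C)OC(=O)N1CCC(O[C@H]2CC[C@H](Oc3ccc(C#N)cc3)CC2)CC1` gives 8.6 nM in this assay.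

Compound 3 carries the lowest of the three numbers, but its gap to compound 2 lies within the usual scatter, so the two cannot be set apart; only compound 1 stands clearly higher. The large step of a 17-fold lower number from compound 1 to compound 2 (1.22 log units; beyond the scatter) goes with the fact that compounds 1 and 2 differ only in the configuration as drawn. The step of a 1.9-fold lower number from compound 2 to compound 3 (0.27 log units; within the scatter) is a small one, within the scatter.

Compound 4 `CC(C)(C)OC(=O)N1CCC(O[C@H]2CC[C@H](Oc3ccc(S(C)(=O)=O)cn3)CC2)CC1` differs from compound 3 by 5-(methylsulfonyl)pyridin-2-yl in place of 4-cyanophenyl on an oxygen on a saturated carbon. The step from compound 2 to compound 3 bears on this change, since it swapped the same two groups on the aromatic ring in the opposite direction and stayed within the scatter. Going by the values given here, no measured step speaks to the ring nitrogen that enters. Compound 4 is therefore expected to return toward the number of compound 2, with a 1.7-fold higher number from compound 3 to compound 4 (0.24 log units; within the scatter) expected to stay within the scatter. The estimate for compound 4 in this assay is 15 nM, in a range from 5 nM to 45 nM.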

Compound 4, half-maximal effective concentration: 47 nM
The estimate for compound 4 lay 3.1-fold (0.50 log units) below the measured number; the measured number lies above the stated range.
By their numbers in this assay, from the lowest: compounds 3 and 2 (each within the scatter of the next); then compound 4; then compound 1.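

Compound 4 shows that the ring nitrogen matters at this place, on an oxygen on a saturated carbon: with the methylsulfonyl group kept, 5-(methylsulfonyl)pyridin-2-yl in place of 4-(methylsulfonyl)phenyl gives a 2.9-fold higher number from compound 2 to compound 4 (0.47 log units; beyond the scatter) in this assay. Against 4-cyanophenyl the same group gives a 5.5-fold higher number from compound 3 to compound 4 (0.74 log units; beyond the scatter) and so opens a gap beyond the scatter, whereas compound 2 and compound 3, which both carry a ring of carbon only, could not be set apart. Nothing in the evidence at hand accounts for this rise, since the only line available concerns configuration.

From the compounds shown here alone, whether a nitrile on the pyridine ring would follow the same rise remains open. So does the reading of this place with an amine or a carboxylic acid on the aromatic ring.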